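Replacing Carboxy with Methylsulfanyl on the Side Chain

The compounds below may be only part of what the source reports. "The series", "measured", "known", "first", "only" and "open" are said of these compounds alone.

In a functional assay on HL-60 cells (Homo sapiens) for cytotoxicity, read by MTT assay, with a stated time of 48 h (a lower number here means a stronger inhibitor, a higher number a weaker inhibitor), compound 2 `CCCCCCCCCC(=O)N[C@@H](CCC(=O)O)C(=O)Nc1ccn([C@H]2O[C@@H](CO)[C@H](O)[C@H]2O)c(=O)n1` gives 1860 nM. Compound 1 `CCCCCCCCCC(=O)N[C@H](C(=O)Nc1ccn([C@H]2O[C@@H](CO)[C@H](O)[C@H]2O)c(=O)n1)C(C)C` gives 2040 nM, so the two lie within the scatter of each other. Compound 3 `CCCCCCCCCC(=O)N[C@@H](CCSC)C(=O)Nc1ccn([C@H]2O[C@@H](CO)[C@H](O)[C@H]2O)c(=O)n1` has methylsulfanyl in place of carboxy on a saturated chain carbon, three bonds along the chain from an amide-type nitrogen and a carbonyl carbon. Going by the values given here, the only measured step bearing on this, a 1.1-fold lower number from compound 1 to compound 2 (0.04 log units; within the scatter), put 2-carboxyethyl in place of isopropyl and stayed within the scatter. No change beyond the scatter is therefore expected in this assay, and the expected step is a 1.0-fold higher number from compound 2 to compound 3 (0.01 log units; within the scatter). Compound 3 is estimated at 1900 nM, with an expected range of 1000 nM to 3800 nM.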

Compound 3, half-maximal inhibitory concentration in the HL-60 assay: 280 nM
Estimate against measurement, compound 3: 6.8-fold (0.83 log units) above, and the stated range ends above it.
By their numbers in the HL-60 assay, from the lowest: compound 3; then compounds 2 and 1 (each within the scatter of the next).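

In the HL-60 assay the side chain at this position clearly matters: methylsulfanyl in place of carboxy gives a 6.6-fold lower number from compound 2 to compound 3 (0.82 log units; beyond the scatter), and 2-(methylsulfanyl)ethyl in place of isopropyl gives a 7.3-fold lower number from compound 1 to compound 3 (0.86 log units; beyond the scatter). The earlier step, which stayed within the scatter, gave no sign that this place could respond so strongly. In a physicochemical assay for lipophilicity (on this read-out lower numbers stand for lower lipophilicity and higher numbers for higher lipophilicity), compound 2 gives -0.28 and compound 3 gives 0.68. The change from carboxy to methylsulfanyl also moves the physicochemical assay: the measured partition coefficient of compound 2, -0.28, and of compound 3, 0.68, a number 0.96 log units higher (beyond the scatter)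

A single pair cannot tie this shift to the stronger inhibition. From the compounds shown here alone, it also remains open whether the sulfur matters, which a methoxy group in place of methylsulfanyl could test.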